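The compounds below may be only part of what the source reports. "The series", "measured", "known", "first", "only" and "open" are said of these compounds alone.

Measured so far in a functional assay on MDA-MB-231 cells (Homo sapiens) for inhibition, read by MTT assay and WST assay, with a stated time of 72 h, tested at 10 uM; a lower number here means less inhibition of growth, a higher number more inhibition of growth at the concentration tested:
- compound 1, `O=C(Nc1ccccc1)Nc1ccc(Oc2ccc(-c3ncc[nH]3)cc2)cc1`, gives 11.4%
- compound 2, `Cc1ccc(NC(=O)Nc2ccc(Oc3ccc(-c4ncc[nH]4)cc3)cc2)cc1`, gives 49.3%

Of these two numbers, compound 2 stands higher. Going by the values given here, the only step between them, a number 37.9 percentage points higher from compound 1 to compound 2 (beyond the scatter), comes from one change: a methyl group in place of a hydrogen on an aromatic carbon of the phenyl ring attached to the urea nitrogen. So the single step measured here shows that a substituent on that ring can move the number a long way.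

Compound 3, `O=C(Nc1ccc(Oc2ccc(-c3ncc[nH]3)cc2)cc1)Nc1cc(Br)cc(C(F)(F)F)c1`, is not yet measured. It differs from compound 2 in one place: 3-bromo-5-(trifluoromethyl)phenyl in place of 4-methylphenyl on an amide-type nitrogen. The ring that carries the methyl in compound 2 is thus exchanged for a ring carrying bromine and trifluoromethyl. Among the compounds with values here, no measured step covers such an exchange directly; the step from compound 1 to compound 2 only shows that this ring is a place where a change matters. With no closer guide, the number for compound 3 is expected to stay near that of compound 2, with a wide margin of uncertainty in either direction, giving an estimated step of a number 5.7 percentage points higher from compound 2 to compound 3 (within the scatter). The estimate for compound 3 in this assay is 55%, with a range from 25% to 85%.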

Compound 3, percent growth inhibition at one concentration: -13.6%
Estimate against measurement, compound 3: 68.6 percentage points above; the whole stated range lies above it.
By their numbers in this assay, from the lowest: compound 3; then compound 1; then compound 2.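

In this assay, the ring on the amide-type nitrogen can push the number down as well as up: the exchange gives a number 62.9 percentage points lower from compound 2 to compound 3 (beyond the scatter), and measured against the unsubstituted ring it gives a number 25 percentage points lower from compound 1 to compound 3 (beyond the scatter). Putting groups on this ring therefore does not bring more growth inhibition as a rule: compound 2 gains on compound 1, while compound 3 goes against that direction and gives -13.6%, a number under zero that shows no growth inhibition at the concentration tested. Nothing available explains why 3-bromo-5-(trifluoromethyl)phenyl behaves so differently from 4-methylphenyl.

Bromine and trifluoromethyl enter together in compound 3, so it stays open whether either one alone on the ring would give a number like that of compound 3 or one closer to that of compound 2. As far as these compounds go, it is also open how the number would respond to an ethyl group in place of the methyl of compound 2, or to an amine or a carboxylic acid on the same ring.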